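The source may report more compounds than this note shows. Statements on the series, on what has been measured and on what is new or still open speak of the compounds shown alone.

Working notes on the series. The shared core of compound 1 `CN(C)CCn1cnnc1-c1cc(Oc2ccc(NC(=O)N/N=C/c3ccc(O)c(O)c3)cc2F)ccn1` carries, on the carbon with a double bond to nitrogen, a 3,4-dihydroxyphenyl; in a functional assay on MKN-45 cells (Homo sapiens) for cytotoxicity, read by MTT assay, with a stated time of 72 h (a lower number here means a stronger inhibitor, a higher number a weaker inhibitor), compound 1 gives 3240 nM. Compound 2 `CN(C)CCn1cnnc1-c1cc(Oc2ccc(NC(=O)N/N=C/c3c(O)ccc4ccccc34)cc2F)ccn1` gives 2020 nM, and compound 3 `COc1ccc(/C=N/NC(=O)Nc2ccc(Oc3ccnc(-c4nncn4CCN(C)C)c3)c(F)c2)cc1O` gives 2510 nM, the second highest of the three values. The steps of a 1.6-fold lower number from compound 1 to compound 2 (0.21 log units; within the scatter), a 1.3-fold lower number from compound 1 to compound 3 (0.11 log units; within the scatter) and a 1.2-fold higher number from compound 2 to compound 3 (0.09 log units; within the scatter) all stay inside the scatter, so the three aryl variants on that carbon are not separated by this assay.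

Compound 4 `CN(C)CCn1cnnc1-c1cc(Oc2ccc(NC(=O)N/N=C/c3cccc(O)c3)cc2F)ccn1` differs from compound 3 by hydrogen in place of methoxy on an aromatic carbon. The step bearing most directly on it is a 1.3-fold lower number from compound 1 to compound 3 (0.11 log units; within the scatter), which changed the same oxygen and moved nothing beyond the scatter; the other two steps, also within the scatter, point the same way. No step beyond the scatter is therefore expected for compound 4, and its value is estimated as 2700 nM, with a range from 1300 nM to 5600 nM. The expected step is a 1.1-fold higher number from compound 3 to compound 4 (0.03 log units; within the scatter) for compound 4.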

Compound 4, half-maximal inhibitory concentration: 1370 nM
Beside the measured number, compound 4's estimate is 2.0-fold (0.29 log units) above it, and the stated range covers the measured number.
By their numbers in this assay, from the lowest: compounds 4, 2, 3 and 1 (each within the scatter of the next, the first and the last beyond it).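

Dropping the methoxy from the aromatic carbon para to a large group gives a 1.8-fold lower number from compound 3 to compound 4 (0.26 log units; within the scatter) and so does not separate 3-hydroxyphenyl from 3-hydroxy-4-methoxyphenyl in this assay, while the comparison with the fused aryl group, a 1.5-fold lower number from compound 2 to compound 4 (0.17 log units; within the scatter), likewise stays inside the scatter. For the compounds shown here, the new information is a 2.4-fold lower number from compound 1 to compound 4 (0.37 log units; beyond the scatter), a modest change with hydrogen in place of hydroxy and the first step at this aryl group to pass the scatter. No available evidence accounts for this step.

Open, as far as these compounds go, is whether an amine or a carboxylic acid on that aromatic carbon would read with hydrogen or with hydroxy. Also open, from the compounds shown here alone, is how an unsubstituted phenyl, lacking the remaining hydroxy as well, would read in this assay.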